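Working notes: 3-methoxyphenyl in place of 4-methoxyphenyl

The compounds below may be only part of what the source reports. "The series", "measured", "known", "first", "only" and "open" are said of these compounds alone.

- compound 1 `O=C(COc1ccc(/C=C/C(=O)c2ccc(F)cc2)cc1)Nc1ccc2c(c1)COC2=O` gives 5420 nM as measured
- compound 2 `COc1ccc(/C=C/C(=O)c2ccc(OCC(=O)Nc3ccc4c(c3)COC4=O)cc2)cc1` gives 3030 nM as measured

In a functional assay on MDA-MB-231 cells (Homo sapiens) for cytotoxicity, read by MTT assay, with a stated time of 48 h (on this read-out lower numbers stand for stronger inhibition and higher numbers for weaker inhibition), compound 2 at 3030 nM and compound 1 at 5420 nM sit within the usual scatter of each other, so the two numbers cannot be ranked.

Compound 3 `COc1cccc(/C=C/C(=O)c2ccc(OCC(=O)Nc3ccc4c(c3)COC4=O)cc2)c1` has the same atoms as compound 2, joined differently: 3-methoxyphenyl in place of 4-methoxyphenyl on a double-bonded chain carbon bound to a double-bonded chain carbon with 3-methoxyphenyl in place of 4-methoxyphenyl on a double-bonded chain carbon bound to a double-bonded chain carbon.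

Among the measured compounds shown here, no measured pair isolates this change, so the data give no direct guide to its size. The expectation starts from compound 2 at 3030 nM and allows no step beyond the scatter in this assay with only a slight, uncertain drift toward weaker inhibition. The expected change is a 1.2-fold higher number from compound 2 to compound 3 (0.06 log units; within the scatter) by this estimate. For compound 3 the estimated value is 3500 nM with an expected range from 1500 nM to 8000 nM in this assay.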

Compound 3, half-maximal inhibitory concentration: 3420 nM
Compound 3: the middle estimate sits 1.0-fold (0.01 log units) above what was measured; measured number inside the range.
By their numbers in this assay, from the lowest: compounds 2, 3 and 1 (each within the scatter of the next).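

In this assay, 3-methoxyphenyl in place of 4-methoxyphenyl on a double-bonded chain carbon bound to a double-bonded chain carbon gives a 1.1-fold higher number from compound 2 to compound 3 (0.05 log units; within the scatter), so the two values cannot be ranked. Among the compounds shown here, this is the first pair that differs in one place, which compound 1 and compound 2 did not offer, and it gives a direct reading for this position. For the compounds shown here, the two groups have the same heavy-atom count and the same hydrogen-bond donor and acceptor counts, and moving the methoxy group between these two named arrangements produces no step that this assay can resolve. No measurement among the data bears on what lies behind this result.

The compounds shown leave open whether any other group at this place, such as 2-methoxyphenyl, unsubstituted phenyl, 3-hydroxyphenyl or a phenyl ring carrying an amine or a carboxylic acid, would move the number beyond the scatter of compound 2. They also leave open whether the same exchange stays within the scatter on a chain with the fluorophenyl group of compound 1.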